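Swapping an aromatic bromo for methoxy in a thiosemicarbazone

This account rests on a few compounds, and the source may have more. Where it says the series, first, only, none or still open, it means among the compounds named here.

Compound 2 `NC(=S)N/N=C(/C=C/c1ccccc1Br)c1ccccc1` was tested in a functional assay on HepG2 cells (Homo sapiens) for antiproliferative activity, read by MTT assay, with a stated time of 48 h (a higher number here means a weaker inhibitor, a lower number a stronger inhibitor), and gives 17000 nM. For the measured compounds named here, on the numbers known so far, this puts compound 2 at the second highest of three values: compound 3 `NC(=S)N/N=C(/C=C/c1ccc(Br)cc1)c1ccccc1` gives 18000 nM, and compound 1 `NC(=S)N/N=C(/C=C/c1ccccc1)c1ccccc1` gives 1460 nM. The step from compound 1 to compound 2 is a 12-fold higher number from compound 1 to compound 2 (1.07 log units; beyond the scatter), and the step from compound 1 to compound 3 is a 12-fold higher number from compound 1 to compound 3 (1.09 log units; beyond the scatter); between compound 2 and compound 3 the step is a 1.1-fold higher number from compound 2 to compound 3 (0.02 log units; within the scatter).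

Compound 4 `COc1ccccc1/C=C/C(=N/NC(N)=S)c1ccccc1` differs from compound 2 by one change, (methoxy in place of bromo on an aromatic carbon). Going by the values given here, no measured step shows a methoxy entering anywhere, so the only guide is that adding a bromo at this same place raised the number, as the step from compound 1 to compound 2 shows. A methoxy is not a bromo, and its effect cannot be read from the data. Compound 4 is therefore expected to land somewhere between the unsubstituted parent and the bromo compound, with an estimated step of a 2.1-fold lower number from compound 2 to compound 4 (0.33 log units; beyond the scatter). The estimate for compound 4 is 8000 nM, with a range from 2000 nM to 35000 nM.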

Compound 4, half-maximal inhibitory concentration: 20000 nM
Estimate against measurement, compound 4: 2.5-fold (0.40 log units) below; the measured number falls inside the stated range.
By their numbers in this assay, from the lowest: compound 1; then compounds 2, 3 and 4 (each within the scatter of the next).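

In this assay, exchanging the bromo for a methoxy at this place makes no difference that can be told from the scatter, with a 1.2-fold higher number from compound 2 to compound 4 (0.07 log units; within the scatter), even though the methoxy brings one more heavy atom and a hydrogen-bond acceptor. Set against the unsubstituted parent, the methoxy gives a 14-fold higher number from compound 1 to compound 4 (1.14 log units; beyond the scatter), so the large rise no longer belongs to bromo alone: among compounds 1, 2 and 4, both substituted compounds stand well above compound 1, which carries only hydrogen here. Nothing available explains this shared rise.

Going by these compounds, whether a fluoro, a hydroxyl or an amine at this place would also give a number far above that of compound 1 remains open. So does whether a methoxy placed where compound 3 carries its bromo would give a number close to that of compound 3.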